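This account rests on a few compounds, and the source may have more. Where it says the series, first, only, none or still open, it means among the compounds named here.

Measured so far in an ADME assay on Huh7.5.1 cells (Homo sapiens) for cytotoxicity, read by ATP content, with a stated time of 48 h; on this read-out lower numbers stand for higher toxicity in this test and higher numbers for lower toxicity in this test:
- compound 1 `Cc1cc(C)c(-c2nc(CN3CCC(C(=O)NCCCN4C[C@H](C)C[C@H](C)C4)CC3)c(C)o2)c(C)c1`: 6570 nM
- compound 2 `Cc1ccccc1-c1nc(CN2CCC(C(=O)NCCCN3CCCCC3)CC2)c(C)o1`: 18100 nM

In this assay compound 1 gives 6570 nM, the lower of the two numbers available. Compound 2 gives 18100 nM, and the gap between the two lies beyond the usual scatter of repeated measurements.

The next compound to be measured is compound 3 `Cc1oc(-c2ccc(Cl)c(Cl)c2)nc1CN1CCC(C(=O)NCCCN2C[C@H](C)C[C@H](C)C2)CC1`. It keeps the rest of compound 1 and carries 3,4-dichlorophenyl in place of 2,4,6-trimethylphenyl on an aromatic carbon. Going by the values given here, no pair of measured compounds differs in one place only, so the data hold no direct measure of what such a change does. Compound 2, at 18100 nM, differs from compound 1 in more than one place and cannot isolate this change. The expectation therefore stays close to compound 1, with no shift beyond the scatter and no firm direction, though the uncertainty is wide. The expected step is a 1.1-fold lower number from compound 1 to compound 3 (0.04 log units; within the scatter). For compound 3 the estimated value is 6000 nM, with an expected range from 2500 nM to 15000 nM.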

Compound 3, half-maximal cytotoxic concentration: 3170 nM
Compound 3: the middle estimate sits 1.9-fold (0.28 log units) above what was measured; the measured number falls inside the stated range.
By their numbers in this assay, from the lowest: compound 3; then compound 1; then compound 2.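

In this assay, going by these compounds alone, the exchange of 2,4,6-trimethylphenyl for 3,4-dichlorophenyl on this aromatic carbon gives a 2.1-fold lower number from compound 1 to compound 3 (0.32 log units; beyond the scatter) and is the first change at this position that can be read on its own, with the rest of the molecule held constant. It shows that this position is not silent: replacing the group here moves the number beyond the scatter, towards higher toxicity in this test, although the step is modest and rests on a single pair. No accompanying measurement bears on why the number moved.

This one step combines the departure of three methyl groups with the arrival of two chlorine atoms, so it cannot say which part of the exchange matters, and a plain phenyl, a 4-chlorophenyl or a 3,4-dimethylphenyl at the same place would be needed to separate them. It also leaves open whether the same exchange would move the number in the same direction on a compound carrying a different amine at the end of the propyl chain, such as a morpholine.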